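A few compounds are considered here, and "the series" means these few. Any claim that something is new, unique, unknown or untested is made for them only; others in the source may bear on it.

Compound 1 `Cc1c(OCCCCOc2ccc(F)c(C(=O)O)c2)ccc(C(=O)CC(C)(C)C)c1O` gives 208 nM in an assay on HEK293 cells for positive allosteric modulation of metabotropic glutamate receptor 2 (Rattus norvegicus), read by thallium flux, with a stated time of 2.5 min; on this read-out lower numbers stand for an effect already at smaller amounts and higher numbers for an effect only at larger amounts of compound.
Compound 2 `Cc1c(OCCCCOc2ccc(C(=O)CC(C)(C)C)c(O)c2C)cccc1C(=O)O` gives 136 nM in this assay.
Compound 3 `CC(=O)c1ccc(OCCCCOc2ccc(F)c(C(=O)O)c2)c(C)c1O` gives 259 nM in this assay.

The three measured compounds share a tether bridging two aryl ethers and differ at two places. Compound 1 and compound 2 differ in the core, with 3-carboxy-2-methylphenyl in place of 3-carboxy-4-fluorophenyl on an oxygen on a saturated carbon; this gives a 1.5-fold lower number from compound 1 to compound 2 (0.18 log units; within the scatter). Compound 1 and compound 3 differ in the acyl group, with hydrogen in place of tert-butyl on a saturated chain carbon bound to a carbonyl carbon; this gives a 1.2-fold higher number from compound 1 to compound 3 (0.10 log units; within the scatter). All three values lie within the scatter of one another, so no order among them can be read.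

Compound 4 `CC(=O)c1ccc(OCCCCOc2cccc(C(=O)O)c2C)c(C)c1O` is not yet measured. It stands to compound 2 as compound 3 stands to compound 1: hydrogen in place of tert-butyl on a saturated chain carbon bound to a carbonyl carbon, the same change at the same place. For the measured compounds named here, a step of similar, small size is expected here as well, a 1.2-fold higher number from compound 2 to compound 4 (0.08 log units; within the scatter), because a 1.2-fold higher number from compound 1 to compound 3 (0.10 log units; within the scatter) sets the only precedent available. Compound 4 is accordingly estimated at 165 nM in this assay, with a likely range from 80 nM to 350 nM.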

Compound 4, half-maximal effective concentration: 200 nM
The estimate for compound 4 lay 1.2-fold (0.08 log units) below the measured number, within the range that was stated.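

In this assay, hydrogen in place of tert-butyl on a saturated chain carbon bound to a carbonyl carbon gives a 1.5-fold higher number from compound 2 to compound 4 (0.17 log units; within the scatter). Set beside the earlier step, the same change behaves alike on the two cores, and the two steps cannot be told apart: the same change on two cores in this assay, a 1.2-fold higher number (0.10 log units; within the scatter) from compound 1 to compound 3 and a 1.5-fold higher number (0.17 log units; within the scatter) from compound 2 to compound 4, 1.2-fold (0.07 log units) apart, within the scatter of two such steps This shows that neopentylcarbonyl and acetyl are interchangeable on these two cores within the resolution of the read-out, but since each step lies within the scatter, it shows neither a real effect of the change on either core nor that the change would stay this small on any further core.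

The compounds shown leave open whether an amine, a hydroxyl or a cyclopropyl ring on that saturated chain carbon would give a step of similar size. They also leave open whether the change would carry over in the same way with a longer chain in the tether between the two aryl ethers.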